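Thienyl amide series: triazolyl variant of compound 3

The source may hold more compounds than are shown below. What is called first, only, known or untested is meant among the compounds shown, and "the series" means these compounds.

Measured so far:
compound 1 `Cc1ccc(C(=O)Nc2sc3c(c2C(N)=O)CCCC3)s1` – 652 nM
compound 2 `CC1(C)Cc2c(sc(NC(=O)c3ccccc3O)c2C(N)=O)C(C)(C)O1` – 4 nM
compound 3 `CC1(C)Cc2c(sc(NC(=O)c3cccnc3O)c2C(N)=O)C(C)(C)O1` – 190 nM

All numbers come from an assay on cells for positive allosteric modulation of Cystic fibrosis transmembrane conductance regulator variant F508del (Homo sapiens), with stated times of 10 min and 7 s, in the presence of a further agent that is not named here; a lower number here means that less compound is needed, a higher number that more compound is needed for the effect. Compound 3 stands second highest of the three; compound 1 sits above it and compound 2 well below it. Among the compounds with values here, the one single-point step at hand is a 48-fold higher number from compound 2 to compound 3 (1.68 log units; beyond the scatter), so changing the aromatic ring on the carbonyl carbon has cost a great deal once already.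

Compound 4 `CC1(C)Cc2c(sc(NC(=O)c3nnc[nH]3)c2C(N)=O)C(C)(C)O1` is the next change on the same carbon: 4H-1,2,4-triazol-3-yl in place of 2-hydroxypyridin-3-yl on a carbonyl carbon. Within the data shown here, no measured step covers this ring swap, but the only related step went upward and was large, so a further rise is expected, giving a 4.2-fold higher number from compound 3 to compound 4 (0.62 log units; beyond the scatter). The estimate for compound 4 in this assay is 800 nM, with a range from 150 nM to 4000 nM.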

Compound 4, half-maximal effective concentration: 467 nM
Compound 4: middle estimate off by 1.7-fold (0.23 log units), on the high side; the measured number falls inside the stated range.
By their numbers in this assay, from the lowest: compound 2; then compound 3; then compounds 4 and 1 (each within the scatter of the next).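

Exchanging 2-hydroxypyridin-3-yl for 4H-1,2,4-triazol-3-yl on the carbonyl carbon gives a 2.5-fold higher number from compound 3 to compound 4 (0.39 log units; beyond the scatter), so a five-membered aromatic ring costs only a modest step relative to compound 3. Measured against 2-hydroxyphenyl, the same ring gives a 120-fold higher number from compound 2 to compound 4 (2.07 log units; beyond the scatter), leaving compound 4 far from compound 2. No evidence on the cause of either step is at hand.

Open, as far as these compounds go, is whether an aminophenyl group in place of 2-hydroxyphenyl on the carbonyl carbon would keep the number of compound 2. Also open, from the compounds shown here alone, is whether a methyl group on the triazole would shift the number of compound 4.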